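Changing the aryl group on the ring-bound nitrogen

This account rests on a few compounds, and the source may have more. Where it says the series, first, only, none or still open, it means among the compounds named here.

Measured compounds:
Compound 1, `O=C(CSc1nc(Nc2ccccc2)c2ccccc2n1)Nc1ccccc1Br`: 14100 nM
Compound 2, `CCc1ccc(NC(=O)CSc2nc(Nc3ccccc3)c3ccccc3n2)cc1`: 33900 nM
Compound 3, `C=CC(=O)Nc1cccc(NC(=O)CSc2nc(Nc3ccccc3F)c3ccccc3n2)c1`: 18700 nM

All three share one core and were tested in a functional assay on MDA-MB-231 cells (Homo sapiens) for inhibition, read by MTT assay, with a stated time of 72 h; on this read-out higher numbers stand for weaker inhibition and lower numbers for stronger inhibition. Compound 3 has the second highest of the three numbers, but its gaps to compound 1 and to compound 2 both lie within the scatter, so no order among them can be claimed. Going by the values given here, the only single-point step measured so far, a 2.4-fold higher number from compound 1 to compound 2 (0.38 log units; beyond the scatter), concerns the group on the amide-type nitrogen.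

Compound 4, `C=CC(=O)Nc1cccc(NC(=O)CSc2nc(Nc3ccc(F)c(Cl)c3)c3ccccc3n2)c1`, differs from compound 3 elsewhere: 3-chloro-4-fluorophenyl in place of 2-fluorophenyl on a nitrogen on an aromatic ring. Among the compounds with values here, no measured step touches this nitrogen, so there is no direct guide. With only the modest step on the other side of the molecule to go by, the expected change in this assay is none beyond the scatter, and the estimated step is a 1.2-fold lower number from compound 3 to compound 4 (0.07 log units; within the scatter). Compound 4 is therefore expected to give about 16000 nM in this assay, within a range from 6000 nM to 42000 nM.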

Compound 4, half-maximal inhibitory concentration: 10600 nM
For compound 4 the middle estimate is 1.5-fold (0.18 log units) above the measured one, and the stated range covers the measured number.
By their numbers in this assay, from the lowest: compounds 4, 1, 3 and 2 (each within the scatter of the next, the first and the last beyond it).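

Going by these compounds alone, this is the first measured step on the aryl group of the ring-bound nitrogen: in this assay, 3-chloro-4-fluorophenyl in place of 2-fluorophenyl gives a 1.8-fold lower number from compound 3 to compound 4 (0.25 log units; within the scatter). The step therefore shows no real change, so at this position a chlorine can be added and the fluorine placed differently on the phenyl ring without a shift that can be told from repeat-to-repeat variation. No measurement of any property of these compounds bears on this result.

On these data alone, it remains open whether any group on this nitrogen can move the number beyond the scatter, since both groups compared here are halogen-bearing phenyl rings. A phenyl ring carrying a carboxylic acid or an amine, or an ethyl chain in place of the ring, would test this.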